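Thiophen-2-yl to 1-benzofuran-2-yl on two cores

A few compounds are considered here, and "the series" means these few. Any claim that something is new, unique, unknown or untested is made for them only; others in the source may bear on it.

Measured so far in a functional assay on CEM-DNR-bulk cells (Homo sapiens), read by MTT assay, with a stated time of 72 h; on this read-out lower numbers stand for stronger inhibition and higher numbers for weaker inhibition:
- Compound 1 `Nc1nc2c(c(-c3cccs3)cn2[C@@H]2O[C@H](CO)[C@@H](O)[C@H]2O)c(=O)[nH]1` gives > 20000 nM, which is a limit of the assay and not a number.
- Compound 2 `CN(C)c1ncnc2c1c(-c1cccs1)cn2[C@@H]1O[C@H](CO)[C@@H](O)[C@H]1O` gives > 20000 nM, again only a limit.
- Compound 3 `Nc1nc2c(c(-c3cc4ccccc4o3)cn2[C@@H]2O[C@H](CO)[C@@H](O)[C@H]2O)c(=O)[nH]1` gives > 20000 nM, likewise a limit.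

Compound 1 and compound 3 share one core and differ in a single place: 1-benzofuran-2-yl in place of thiophen-2-yl on an aromatic carbon. The size of this step, a step that the two limits leave unreadable from compound 1 to compound 3, cannot be read because of the limit of > 20000 nM in this assay, at which 3 of the 3 values shown sit. Compound 2 carries a different core; how the two cores differ is not broken down here. Compound 4 `CN(C)c1ncnc2c1c(-c1cc3ccccc3o1)cn2[C@@H]1O[C@H](CO)[C@@H](O)[C@H]1O` has not yet been measured; it carries the same change on the core of compound 2: 1-benzofuran-2-yl in place of thiophen-2-yl on an aromatic carbon. The surroundings of the place are described in the same words for both pairs, so this is the same change.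

For compound 2 only a limit is known, > 20000 nM. The step from compound 2 to compound 4 is expected to be a step that the limit leaves unreadable from compound 2 to compound 4, an expectation that rests on the unreadable measured step that the two limits leave unreadable from compound 1 to compound 3. Compound 4 is therefore estimated at 30000 nM, between 10000 nM and 100000 nM, most likely reported again only as a limit.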

Compound 4, half-maximal inhibitory concentration: > 20000 nM
Compound 4 was reported as a limit; the forecaster's own chance of this, stated with the estimate: 85%; the middle value does not contradict the limit.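

In this assay compound 4 gives > 20000 nM, which is a limit of the assay and not a number. No size can be read for the change from compound 2 to compound 4, because the values all stop at the same point: the limit of > 20000 nM in this assay, at which 4 of the 4 values shown sit. The compounds shown leave open how strongly any of them inhibits these cells, and whether 1-benzofuran-2-yl and thiophen-2-yl differ at all on either core.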